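Series notes: methyl replaced by hydrogen on the aromatic ring

A few compounds are considered here, and "the series" means these few. Any claim that something is new, unique, unknown or untested is made for them only; others in the source may bear on it.

Measured compounds:
compound 1 `Cc1ccnc(/C(N)=N/NC(=S)N2CCCC2)c1` — 86%
compound 2 `Cc1ccnc(/C(N)=N/NC(=S)N2CCCCC2)c1` — 81.2%

In a functional assay on A-375 cells (Homo sapiens) for cytotoxicity, read by MTT assay, with a stated time of 72 h, tested at 10 uM (on this read-out lower numbers stand for less inhibition of growth and higher numbers for more inhibition of growth at the one concentration tested), compound 1 gives 86% and compound 2 gives 81.2%. Going by the values given here, compound 1 and compound 2 cannot be separated on this read-out: the only measured step, a number 4.8 percentage points lower from compound 1 to compound 2 (within the scatter), exchanges piperidin-1-yl for pyrrolidin-1-yl on the thiocarbonyl carbon and stays within the scatter.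

Compound 3 `N/C(=N\NC(=S)N1CCCC1)c1ccccn1` is not yet measured. Its change from compound 1 is hydrogen in place of methyl on an aromatic carbon. Among the compounds with values here, no measured step touches the aromatic carbon; the one step recorded changes a different place and was within the scatter, so it gives no direction for this change. Without a bearing step, the expected step of a number 6 percentage points lower from compound 1 to compound 3 (within the scatter) is one of no change beyond the scatter. Compound 3 is therefore estimated at 80%, with a range from 60% to 95%.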

Compound 3, percent growth inhibition at one concentration: 83.9%
Compound 3: the middle estimate sits 3.9 percentage points below what was measured, within the range that was stated.
By their numbers in this assay, from the lowest: compounds 2, 3 and 1 (each within the scatter of the next).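

Hydrogen in place of methyl on this aromatic carbon, opposite the ring nitrogen, gives a number 2.1 percentage points lower from compound 1 to compound 3 (within the scatter) in this assay. Going by these compounds alone, this is the first measured change on the aromatic ring, and it shows that, with the pyrrolidin-1-yl group in place, the methyl is not required for the growth inhibition seen at the one concentration tested, whereas the earlier pair varied only the group on the thiocarbonyl carbon. No measurement available here accounts for this result.

The compounds shown leave open whether the same exchange holds with piperidin-1-yl on the thiocarbonyl carbon, since only one pair reads this position. They also leave open how a different group on this aromatic carbon, such as an amine, a carboxylic acid or a longer alkyl chain, would read.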